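Fluoro on the sulfonyl ring of the methoxy analogue

The source may hold more compounds than are shown below. What is called first, only, known or untested is meant among the compounds shown, and "the series" means these compounds.

Three acyl sulfonamides have been measured in a functional assay on B16-F10 cells (Mus musculus) for antiproliferative activity, read by ELISA and MTT assay, with a stated time of 48 h; on this read-out lower numbers stand for stronger inhibition and higher numbers for weaker inhibition. Compound 1 `O=C(/C=C/c1ccc(F)cc1)NS(=O)(=O)c1ccc(F)cc1` gives 0.8 ug/mL, and compound 2 `O=C(/C=C/c1ccc(Br)cc1)NS(=O)(=O)c1ccc(F)cc1` gives 1.2 ug/mL. Among the measured compounds shown here, the step of a 1.5-fold higher number from compound 1 to compound 2 (0.18 log units; within the scatter) is the only one-place change measured so far, and it stays within the scatter. Compound 3 `COc1ccc(/C=C/C(=O)NS(=O)(=O)c2ccccc2)cc1` gives 13.2 ug/mL, the highest of the three numbers, and its gap to both compound 1 and compound 2 lies well beyond the scatter.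

Compound 4 `COc1ccc(/C=C/C(=O)NS(=O)(=O)c2ccc(F)cc2)cc1` is compound 3 with fluoro in place of hydrogen on an aromatic carbon. For the measured compounds named here, no measured step covers this change: the single step on record sits on the other ring, at the cinnamoyl end, and it was within the scatter. Compound 1 and compound 2 both carry the fluorinated sulfonyl ring and give the two low numbers, but each also differs from compound 3 at the cinnamoyl end, so their values do not isolate the effect of the sulfonyl-ring fluoro alone. The expectation for compound 4 is therefore a number near that of compound 3, with room for a modest move toward lower numbers and wide uncertainty. The step expected in this assay is a 1.9-fold lower number from compound 3 to compound 4 (0.28 log units; within the scatter), resting on no measured parallel. Compound 4 is estimated in this assay at 7 ug/mL, with a range from 2 ug/mL to 20 ug/mL.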

Compound 4, half-maximal inhibitory concentration: 5.1 ug/mL
Compound 4: the middle estimate sits 1.4-fold (0.14 log units) above what was measured; measured number inside the range.
By their numbers in this assay, from the lowest: compounds 1 and 2 (each within the scatter of the next); then compound 4; then compound 3.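

In this assay, the change from phenyl to 4-fluorophenyl on the sulfonyl side gives a 2.6-fold lower number from compound 3 to compound 4 (0.41 log units; beyond the scatter), the first step read at this position, with the methoxy group held constant at the cinnamoyl end. With the 4-fluorophenyl group held constant on the sulfonyl side, the cinnamoyl end can now also be read against methoxy: the change from bromo gives a 4.3-fold higher number from compound 2 to compound 4 (0.63 log units; beyond the scatter), and the change from fluoro gives a 6.4-fold higher number from compound 1 to compound 4 (0.80 log units; beyond the scatter). The earlier bromo-for-fluoro step stayed within the scatter, whereas these results show that single changes on either ring can move the number beyond it, at least among these four compounds.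

No measurement on hand accounts for these steps.

Whether fluoro in place of hydrogen on the sulfonyl ring gives a similar step when fluoro or bromo occupies the cinnamoyl end remains open, since the series shown holds that comparison only for the methoxy pair. Also open, from the compounds shown here alone, is how a chloro group, an amine or a carboxylic acid would read at the sulfonyl-ring position now occupied by fluoro.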